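Swapping the Tetrazole on the Sulfur of Compound 3

A few compounds are considered here, and "the series" means these few. Any claim that something is new, unique, unknown or untested is made for them only; others in the source may bear on it.

Three measured compounds share one core and differ only in the group on the sulfur. Compound 1 `Cn1c(-c2ccc(NC(=O)CSc3nc4ccccc4o3)cc2)nc(-c2ccccc2)c1-c1ccccc1` gives 41% in a functional assay on HT-29 cells (Homo sapiens) for cytotoxicity, read by MTT assay, with a stated time of 24 h, tested at 1.6 ug/mL; a higher number here means a stronger effect of the compound at the concentration tested, a lower number a weaker effect. Compound 2 `Cc1ccc2oc(SCC(=O)Nc3ccc(-c4nc(-c5ccccc5)c(-c5ccccc5)n4C)cc3)nc2c1` gives 15.5% in this assay, and compound 3 `Cn1nnnc1SCC(=O)Nc1ccc(-c2nc(-c3ccccc3)c(-c3ccccc3)n2C)cc1` gives 49.8%, the highest of the three numbers, though its gap to compound 1 lies within the scatter. Compound 4 `Cn1c(-c2ccc(NC(=O)CSC3=NCCS3)cc2)nc(-c2ccccc2)c1-c1ccccc1` differs from compound 3 in one place: a group of 5 heavy atoms (3 carbon, 1 nitrogen, 1 sulfur; one five-membered non-aromatic ring with 2 hetero atoms) in place of a group of 6 heavy atoms (2 carbon, 4 nitrogen; one five-membered aromatic ring with 4 hetero atoms), on a sulfur. Among the compounds with values here, the steps that bear on this both change the group on the sulfur: a number 8.8 percentage points higher from compound 1 to compound 3 (within the scatter) and a number 34.3 percentage points higher from compound 2 to compound 3 (beyond the scatter). Because a number 8.8 percentage points higher from compound 1 to compound 3 (within the scatter) stayed within the scatter while a number 34.3 percentage points higher from compound 2 to compound 3 (beyond the scatter) was large, the direction for compound 4 is uncertain, and a modest drop is expected in this assay. Compound 4 is estimated at 38%, between 15% and 60%. The expected step is a number 11.8 percentage points lower from compound 3 to compound 4 (beyond the scatter).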

Compound 4, a percentage reported as activity, at one concentration (the size of the read-out at that concentration, not a potency): 30.4%
Compound 4: the middle estimate sits 7.6 percentage points above what was measured; the range from low to high includes it.
By their numbers in this assay, from the lowest: compound 2; then compound 4; then compounds 1 and 3 (each within the scatter of the next).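

Within the data shown here, with a non-aromatic ring on the sulfur, compound 4 separates from the earlier compounds in this assay, showing a number 19.4 percentage points lower from compound 3 to compound 4 (beyond the scatter) and a number 10.6 percentage points lower from compound 1 to compound 4 (beyond the scatter) but also a number 14.9 percentage points higher from compound 2 to compound 4 (beyond the scatter). An aromatic group on this sulfur is therefore not needed for activity in this assay, though the two aromatic groups without a methyl group both read higher here. Nothing measured here explains these steps. As far as these compounds go, what an ethyl chain or a ring carrying a carboxylic acid would give on this sulfur stays open, as does whether the ring sulfur or the loss of aromaticity drives the drop.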